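Swapping the Ring on the Side Chain of Compound 1

The compounds below may be only part of what the source reports. "The series", "measured", "known", "first", "only" and "open" are said of these compounds alone.

Measured compounds:
- compound 1 `CCO/C(O)=C1\C(COCCN2CC(=O)N=C2N)=NC(C)=C(C(=O)OC)C1c1ccccc1Cl` gives 20 nM in a functional assay (aorta) with Rattus norvegicus as the target; on this read-out higher numbers stand for weaker inhibition and lower numbers for stronger inhibition
- compound 2 `CCO/C(O)=C1\C(COCCN2CC(=O)NC2=O)=NC(C)=C(C(=O)OC)C1c1cccc(Cl)c1Cl` gives 3.16 nM in this assay
- compound 3 `CCO/C(O)=C1\C(COCCn2cc(C(N)=O)nn2)=NC(C)=C(C(=O)OC)C1c1cccc(Cl)c1Cl` gives 3.16 nM in this assay

Among these three, compound 1 has the highest number in this assay, which on this read-out means the weakest inhibition; its gap to compound 2 and to compound 3 lies beyond the usual scatter.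

Compound 4 `CCOC(=O)c1cn(CCOCC2=NC(C)=C(C(=O)OC)C(c3ccccc3Cl)/C2=C(\O)OCC)nn1` is not yet measured. It keeps the core of compound 1 and differs in one place: a group of 10 heavy atoms (5 carbon, 3 nitrogen, 2 oxygen; one five-membered aromatic ring with 3 hetero atoms) in place of a group of 7 heavy atoms (3 carbon, 3 nitrogen, 1 oxygen; one five-membered non-aromatic ring with 2 hetero atoms), on a saturated chain carbon, two bonds along the chain from an oxygen on a saturated carbon

Among the compounds with values here, one measured step bears on this kind of swap. The step of no change at the digits printed from compound 2 to compound 3 (within the scatter) exchanged a five-membered non-aromatic ring for a 1,2,3-triazole ring at the same position on the side chain, and the number did not move beyond the scatter. By analogy, the swap from compound 1 to compound 4 is expected to leave the number about where it is, giving no change at the digits printed from compound 1 to compound 4 (within the scatter). The estimate for compound 4 in this assay is therefore 20 nM, expected to fall between 6 nM and 63 nM.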

Compound 4, half-maximal inhibitory concentration: 50.1 nM
Estimate against measurement, compound 4: 2.5-fold (0.40 log units) below, within the range that was stated.
By their numbers in this assay, from the lowest: compounds 2 and 3 (each within the scatter of the next); then compound 1; then compound 4.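

In this assay, this place on the side chain does respond to the group it carries: 4-(ethoxycarbonyl)-1H-1,2,3-triazol-1-yl brings a 2.5-fold higher number from compound 1 to compound 4 (0.40 log units; beyond the scatter), a modest loss of inhibition, whereas the earlier step showed no change at the digits printed from compound 2 to compound 3 (within the scatter). A 1,2,3-triazole here therefore does not leave the number in place in every case, although the two steps start from different rings and end with different groups on the triazole. No measurement at hand gives a reason for this shift.

On these data alone, this step changes the ring and brings in the ethyl ester together, so the share of each in the shift stays open. A carboxylic acid in place of the ethyl ester on the triazole, on the core of compound 1, would help to separate the two.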